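Two swaps on one thiocarbamate-triazole core

A few compounds are considered here, and "the series" means these few. Any claim that something is new, unique, unknown or untested is made for them only; others in the source may bear on it.

Compound 1 `CC(C)NC(=O)N1CCN(C(=S)SCc2cn(Cc3ccc(F)cc3)nn2)CC1` and compound 2 `CCN(C)C(=O)N1CCN(C(=S)SCc2cn(Cc3ccc(F)cc3)nn2)CC1` share a core and differ in a single place: ethyl(methyl)amino in place of isopropylamino on a carbonyl carbon. In a functional assay on EC9706 cells (Homo sapiens) for cytotoxicity, read by MTT assay, with a stated time of 72 h (on this read-out higher numbers stand for weaker inhibition and lower numbers for stronger inhibition), compound 1 gives 12200 nM. In this assay compound 2 gives 14300 nM. The step of a 1.2-fold higher number from compound 1 to compound 2 (0.07 log units; within the scatter) lies within the scatter, so the two numbers are not told apart. Compound 3 `COc1ccc(Cn2cc(CSC(=S)N3CCN(C(=O)NC(C)C)CC3)nn2)cc1` differs from compound 1 by methoxy in place of fluoro on an aromatic carbon. In this assay compound 3 reaches only > 128000 nM, which is a limit of the assay and not a number. Among the three values shown, one sits at the limit of > 128000 nM in this assay, at which 1 of the 3 values shown sits. The step of an at least 10-fold higher number from compound 1 to compound 3 (1.02 log units; beyond the scatter) is large and beyond the scatter.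

Compound 4 `CCN(C)C(=O)N1CCN(C(=S)SCc2cn(Cc3ccc(OC)cc3)nn2)CC1` has not yet been measured. It differs from compound 3 by ethyl(methyl)amino in place of isopropylamino on a carbonyl carbon, the same change made from compound 1 to compound 2, on the same place. That change gave a 1.2-fold higher number from compound 1 to compound 2 (0.07 log units; within the scatter), and on this rests the expectation. The expected step is a step that the limit leaves unreadable from compound 3 to compound 4. For compound 4 the estimate in this assay is 150000 nM, expected to fall between 60000 nM and 400000 nM, with a good chance that only a limit is returned.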

Compound 4, half-maximal inhibitory concentration: > 128000 nM
Compound 4: a limit, no number (the forecaster's own chance of this, stated with the estimate: 70%); the middle value lies beyond the limit too.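

In this assay compound 4 gives > 128000 nM, which is a limit of the assay and not a number. Methoxy in place of fluoro on an aromatic carbon, carried onto the core of compound 2, gives an at least 8.9-fold higher number from compound 2 to compound 4 (0.95 log units; beyond the scatter), so the large loss seen with the isopropylamino compounds recurs with the ethyl(methyl)amino compounds, though its true size stays unknown on both: the same change on two cores in this assay, an at least 10-fold higher number (1.02 log units; beyond the scatter) from compound 1 to compound 3 and an at least 8.9-fold higher number (0.95 log units; beyond the scatter) from compound 2 to compound 4; the limit leaves it open whether they differ. Ethyl(methyl)amino in place of isopropylamino gave a 1.2-fold higher number from compound 1 to compound 2 (0.07 log units; within the scatter) on the fluoro core, but the step between the two methoxy compounds cannot be read, so nothing shows whether that result carries over: the limit of > 128000 nM in this assay, at which 2 of the 4 values shown sit.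

As far as these compounds go, it remains open how a chloro or a nitrile in place of fluoro on the aromatic carbon would read in this assay. From the compounds shown here alone, it is also open whether a longer chain or a cyclic amine such as morpholine on the carbonyl carbon would give a value that can be told apart from those of compound 1 and compound 2.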